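A Methyl Added Before the Measurement Is Known

A few compounds are considered here, and "the series" means these few. Any claim that something is new, unique, unknown or untested is made for them only; others in the source may bear on it.

Of the compounds shown here, two have so far been tested in an assay for inhibition of HSP60/HSP10 (Homo sapiens), with a stated time of 60 min; a higher number here means a weaker inhibitor, a lower number a stronger inhibitor. Compound 1 is `COc1c(Br)cc(Br)cc1C(=O)Nc1ccccc1`. In this assay compound 1 gives > 100000 nM, which is a limit of the assay rather than a number. Compound 2 is `O=C(Nc1ccccc1)c1cccc(Br)c1O`. In this assay compound 2 gives > 100000 nM, again a limit of the assay and not a number. Compound 2 therefore stands where compound 1 stands: the limit of > 100000 nM in this assay, at which 2 of the 2 values shown sit. Nothing in the numbers shown separates the two, and neither can be called stronger or weaker than the other.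

Compound 3, `COc1c(Br)cccc1C(=O)Nc1ccccc1`, is the compound that waits to be measured. It differs from compound 2 in a single place: methyl in place of hydrogen on an oxygen on an aromatic ring. Both measured compounds sit at the limit, so the step is expected to be a step that the limit leaves unreadable from compound 2 to compound 3 in this assay, which means no movement beyond the usual scatter. Compound 3 is accordingly expected to give about 150000 nM, within a range from 30000 nM to 600000 nM, and most likely to return only a limit again.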

Compound 3, half-maximal inhibitory concentration: > 100000 nM
Compound 3 was reported as a limit; the forecaster's own chance of this, stated with the estimate: 85%; the middle value lies beyond the limit too.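

In this assay compound 3 gives > 100000 nM as a limit and not a number. For the compounds shown here, its steps from compound 1 and from compound 2 therefore cannot be read, so this result adds no new step. The compounds shown leave open which change to the shared core, if any, would give a readable value, since all three stand together: the limit of > 100000 nM in this assay, at which 3 of the 3 values shown sit.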